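The source may report more compounds than this note shows. Statements on the series, on what has been measured and on what is new or still open speak of the compounds shown alone.

Three close relatives of compound 2 `COc1ccc(-c2cc(C(=O)/C=C/c3ccc(C)cc3)nc3cc(-c4ccccc4)nn23)cc1OC` have been run in a functional assay on DU-145 cells (Homo sapiens) for antiproliferative activity, read by MTT assay, with a stated time of 24 h; a higher number here means a weaker inhibitor, a lower number a stronger inhibitor. Compound 1 `COc1ccc(C(=O)/C=C/c2cc(-c3cc(OC)c(OC)c(OC)c3)n3nc(-c4ccccc4)cc3n2)cc1` gives 25200 nM in this assay, compound 2 gives 19500 nM, and compound 3 `COc1cc(-c2cc(/C=C/C(=O)c3ccc(C)c(C)c3)nc3cc(-c4ccccc4)nn23)cc(OC)c1OC` gives 15400 nM. Compound 2 thus stands second highest of the three numbers; its nearest neighbour is compound 3 and its furthest is compound 1, and both gaps lie within the scatter of this assay, so no ranking among the three can be drawn from them.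

Within the data shown here, the only one-place step among the measured compounds, a 1.6-fold lower number from compound 1 to compound 3 (0.21 log units; within the scatter), swaps the substitution pattern on the aryl ring attached to the carbonyl carbon and leaves the number essentially unchanged.

Compound 4 `COc1ccc(-c2cc(/C=C/C(=O)c3ccccc3)nc3cc(-c4ccccc4)nn23)cc1OC` differs from compound 2 in one place: 2-benzoylethenyl in place of (2-(4-methylphenyl)ethenyl)carbonyl on an aromatic carbon. The change again touches only the aryl ring of the enone arm, removing its methyl group. Among the measured compounds shown here, the one step that bears on such a change, from compound 1 to compound 3, was within the scatter, and no other measured pair speaks to it. The step from compound 2 to compound 4 in this assay is therefore expected to be small, with no direction that can be called beyond the scatter, that is a 1.0-fold higher number from compound 2 to compound 4 (0.01 log units; within the scatter). On that basis compound 4 is estimated to give 20000 nM in this assay, with a plausible range from 9000 nM to 45000 nM.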

Compound 4, half-maximal inhibitory concentration: 10000 nM
Compound 4: middle estimate off by 2.0-fold (0.30 log units), on the high side, within the range that was stated.
By their numbers in this assay, from the lowest: compounds 4, 3, 2 and 1 (each within the scatter of the next, the first and the last beyond it).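

In this assay, among these compounds, the step of a 2.0-fold lower number from compound 2 to compound 4 (0.29 log units; within the scatter) shows that the arm on this aromatic carbon, next to the ring nitrogen, can be exchanged in a way the earlier compounds did not cover. Where the one earlier step changed only the substituents on the aryl ring, this exchange also turns the arm around: in compound 2 the carbonyl is bonded to the core and the ethenyl carries the 4-methylphenyl ring, whereas in compound 4 the ethenyl is bonded to the core and the carbonyl carries an unsubstituted phenyl ring, and even this double change stays within the scatter. Nothing available bears on why the number moves as it does in this step.

The compounds shown include no pair that separates the turning of the arm from the loss of the methyl group, so the share of each in the step remains unknown. Also open, on these data alone, is how the number would respond to an amine or a carboxylic acid on the aryl ring of the arm, or to a saturated two-carbon chain in place of the ethenyl link.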